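Methyl added to the fused ring of compound 1

The compounds below may be only part of what the source reports. "The series", "measured", "known", "first", "only" and "open" are said of these compounds alone.

Compound 1 `CO[C@H]1CC[C@H](NC(=O)c2n[nH]cc2NC(=O)c2cnc3ccccn23)CC1` gives 5900 nM in an ADME assay on MRC5 cells (Homo sapiens) for inhibition, with a stated time of 72 h (on this read-out higher numbers stand for an effect only at larger amounts of compound and lower numbers for an effect already at smaller amounts), the second highest of the three numbers recorded. Compound 2 `COc1ccccc1C(=O)Nc1c[nH]nc1C(=O)N[C@H]1CC[C@H](OC)CC1` gives 1500 nM in this assay, and compound 3 `CO[C@H]1CC[C@H](NC(=O)c2n[nH]cc2NC(=O)c2ccc(F)cc2F)CC1` gives 11000 nM. The steps among them all replace the whole group on the carbonyl carbon: a 3.9-fold lower number from compound 1 to compound 2 (0.59 log units; beyond the scatter), a 1.9-fold higher number from compound 1 to compound 3 (0.27 log units; within the scatter) and a 7.3-fold higher number from compound 2 to compound 3 (0.87 log units; beyond the scatter).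

Compound 4 `CO[C@H]1CC[C@H](NC(=O)c2n[nH]cc2NC(=O)c2c(C)nc3ccccn23)CC1` keeps the fused bicyclic group of compound 1 and differs only as methyl in place of hydrogen on an aromatic carbon. Within the data shown here, no measured step touches that position; the known steps exchange the entire acyl group rather than add a small substituent to it, so they do not bear directly on this change. With nothing in the series pointing either way, the expected step is no change at the digits printed from compound 1 to compound 4 (within the scatter), that is no movement beyond the scatter. Compound 4 is therefore estimated at 5900 nM in this assay, with a range from 2500 nM to 14000 nM.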

Compound 4, half-maximal effective concentration: 34000 nM
Compound 4: the middle estimate sits 5.8-fold (0.76 log units) below what was measured, outside the stated range (above it).
By their numbers in this assay, from the lowest: compound 2; then compounds 1 and 3 (each within the scatter of the next); then compound 4.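

In this assay this aromatic carbon of the fused system proves sensitive to a single added carbon, with a 5.8-fold higher number from compound 1 to compound 4 (0.76 log units; beyond the scatter) as the step for methyl in place of hydrogen. This one-atom change lies beyond the scatter, whereas exchanging the whole acyl group gives a 1.9-fold higher number from compound 1 to compound 3 (0.27 log units; within the scatter) and stays within it, so a small change at this position can matter more than a complete replacement of that group. No measurement here gives a reason for the step.

Going by these compounds, whether the higher number is particular to methyl stays open, since ethyl, chlorine or an amine on this carbon could move it further, leave it or bring it back. On these data alone, it is also open whether methyl at other carbons of the fused system gives a step of this size.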